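Oxazole piperazine amides: aryl swap on the ring nitrogen

A few compounds are considered here, and "the series" means these few. Any claim that something is new, unique, unknown or untested is made for them only; others in the source may bear on it.

Compound 1 `Cc1nc(-c2ccccc2)c(C(=O)N2CCN(c3ccc(Cl)c(Cl)c3)CC2)o1` is the reference point of the pair measured in a functional assay on HL-60 cells (Homo sapiens) for inhibition, read by MTT assay, with a stated time of 72 h; on this read-out higher numbers stand for weaker inhibition and lower numbers for stronger inhibition. In this assay compound 1 gives 124 nM, the higher of the two numbers recorded. Compound 2 `Cc1nc(-c2ccccc2F)c(C(=O)N2CCN(c3cc(Cl)cc(Cl)c3)CC2)o1` differs from it in more than one place, and in this assay compound 2 gives 60.2 nM, a gap beyond the usual scatter; as the two structures differ in several places, no single change can be read from that pair.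

Compound 3 `Cc1ccc(N2CCN(C(=O)c3oc(C)nc3-c3ccccc3)CC2)cc1` is not yet measured. It differs from compound 1 by 4-methylphenyl in place of 3,4-dichlorophenyl on an amine nitrogen in a ring. Within the data shown here, no measured pair isolates this change, so the size of the step is uncertain. A step toward weaker inhibition, somewhat beyond the scatter, is expected from compound 1 to compound 3 a 2.8-fold higher number from compound 1 to compound 3 (0.45 log units; beyond the scatter). Compound 3 is accordingly estimated at 350 nM in this assay, with a plausible range from 100 nM to 1500 nM.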

Compound 3, half-maximal inhibitory concentration: > 1000 nM
Compound 3: only a limit was reported (the forecaster's own chance of this, stated with the estimate: 10%); middle value at least 2.8-fold (0.45 log units) away from the limit.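

In this assay compound 3 carries a limit, > 1000 nM, and not a number. Placing 4-methylphenyl in place of 3,4-dichlorophenyl on the amine nitrogen in a ring, with the rest of the core of compound 1 unchanged, gives an at least 8.0-fold higher number from compound 1 to compound 3 (0.90 log units; beyond the scatter), the first step in the series that isolates one place and shows that inhibition here depends on the group at this position. The step has a floor but no known upper end, since its reading rests on a limit: the limit of > 1000 nM in this assay, at which 1 of the 3 values shown sits.

The swap removes both chlorine atoms and adds a methyl at once, so the compounds shown do not tell which part carries the step, and a 4-chlorophenyl group at this nitrogen would separate the two. Compound 2 differs from compound 1 in more than one place, so it cannot settle this.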